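Rearranging the lactone ring of compound 2

The compounds below may be only part of what the source reports. "The series", "measured", "known", "first", "only" and "open" are said of these compounds alone.

Measured so far:
compound 1, `C=C1CC[C@@H]2[C@](C)(CCC[C@]2(C)C(=O)O[C@@H]2O[C@H](CO)[C@@H](O)[C@H](O)[C@H]2O)[C@H]1CC/C(=C/CO)CO`, 152000 nM
compound 2, `C=C1CC[C@@H]2[C@](C)(CCC[C@]2(C)C(=O)O[C@@H]2O[C@H](CO)[C@@H](O)[C@H](O)[C@H]2O)[C@H]1CCC1=CCOC1=O`, 65800 nM

For the measured compounds named here, in a functional assay on BV-2 cells (Mus musculus) for inhibition, read by Griess assay, with a stated time of 24 h (a lower number here means a stronger inhibitor, a higher number a weaker inhibitor), compound 2 gives the lowest of the two numbers; the only neighbour is compound 1, and the step of a 2.3-fold lower number from compound 1 to compound 2 (0.36 log units; beyond the scatter) is modest. Compound 3, `C=C1CC[C@@H]2[C@](C)(CCC[C@]2(C)C(=O)O[C@@H]2O[C@H](CO)[C@@H](O)[C@H](O)[C@H]2O)[C@H]1CCC1=CC(=O)OC1`, is not yet measured. It differs from compound 2 as follows: a group of 6 heavy atoms (4 carbon, 2 oxygen; one five-membered non-aromatic ring with 1 hetero atom) in place of a group of 6 heavy atoms (4 carbon, 2 oxygen; one five-membered non-aromatic ring with 1 hetero atom), on a saturated chain carbon, two bonds along the chain from a saturated ring carbon. Going by the values given here, the one measured step bears on it only loosely, since that step exchanged a chain for a ring, whereas here the same atoms are merely joined differently. No step beyond the scatter is therefore expected in this assay. Compound 3 is estimated at 65000 nM, between 25000 nM and 160000 nM, a step of a 1.0-fold lower number from compound 2 to compound 3 (0.01 log units; within the scatter) from compound 2.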

Compound 3, half-maximal inhibitory concentration: 54100 nM
Compound 3: the middle estimate sits 1.2-fold (0.08 log units) above what was measured, and the stated range covers the measured number.
By their numbers in this assay, from the lowest: compounds 3 and 2 (each within the scatter of the next); then compound 1.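

In this assay, joining the same lactone atoms differently gives a 1.2-fold lower number from compound 2 to compound 3 (0.09 log units; within the scatter), so at this position the two ring arrangements cannot be told apart. The advantage over the open chain of compound 1 also holds for the rearranged ring, with a 2.8-fold lower number from compound 1 to compound 3 (0.45 log units; beyond the scatter), and so does not depend on which of the two arrangements is present. Nothing available explains either result.

The compounds shown leave open how a five-membered lactam or a carboxylic acid at this position would compare.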